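The source may report more compounds than this note shows. Statements on the series, on what has been measured and on what is new or still open speak of the compounds shown alone.

Measured in a functional assay on HeLa cells (Homo sapiens) for antiproliferative activity, read by MTT assay, with a stated time of 48 h; on this read-out higher numbers stand for weaker inhibition and lower numbers for stronger inhibition:
Compound 1 `Clc1ccc2[nH]c(-c3cn(-c4ccccc4)nc3-c3ccccc3)nc2c1` gives 3480 nM
Compound 2 `Brc1ccc2[nH]c(-c3cn(-c4ccccc4)nc3-c3ccccc3)nc2c1` gives 1760 nM
Compound 3 `COc1ccc2[nH]c(-c3cn(-c4ccccc4)nc3-c3ccccc3)nc2c1` gives 2870 nM

The steps of a 2.0-fold lower number from compound 1 to compound 2 (0.30 log units; within the scatter) and a 1.6-fold higher number from compound 2 to compound 3 (0.21 log units; within the scatter) both lie within the scatter, so compound 2 cannot be ranked among these three. Compound 4 `Fc1ccc(-c2nn(-c3ccccc3)cc2-c2nc3cc(Br)ccc3[nH]2)cc1` keeps the bromo of compound 2 and changes another place: fluoro in place of hydrogen on an aromatic carbon (fluoro in place of hydrogen on an aromatic carbon, phenyl to 4-fluorophenyl). Within the data shown here, no measured step touches that place. The nearest guide, the swap a 1.2-fold lower number from compound 1 to compound 3 (0.08 log units; within the scatter) along with the two above, stayed within the scatter, yet it says little about a new fluoro. So no step beyond the scatter is expected in this assay here. An estimated 1.0-fold lower number from compound 2 to compound 4 (0.02 log units; within the scatter) is what this suggests. For compound 4 the estimated value is 1700 nM with 700 nM to 4000 nM as the expected range.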

Compound 4, half-maximal inhibitory concentration: 4940 nM
Compound 4: middle estimate off by 2.9-fold (0.46 log units), on the low side, and the stated range ends below it.
By their numbers in this assay, from the lowest: compounds 2, 3, 1 and 4 (each within the scatter of the next, the first and the last beyond it).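

In this assay the change from phenyl to 4-fluorophenyl gives a 2.8-fold higher number from compound 2 to compound 4 (0.45 log units; beyond the scatter) and is the only step shown that lies beyond the scatter; the swaps among chloro, bromo and methoxy all stayed within it. This place, on an aromatic carbon para to a large group, therefore responds to a single fluoro, with weaker inhibition. No measured evidence here explains this step.

Still open, as far as these compounds go, is whether an amine or a carboxylic acid at this place would shift the number in the same direction, and whether fluoro would act alike alongside chloro or methoxy instead of bromo.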